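Lengthening an ester chain further: cytotoxicity on lung cells

The source may report more compounds than this note shows. Statements on the series, on what has been measured and on what is new or still open speak of the compounds shown alone.

Compound 2 `CCCCCCCCCCCCCCOC(=O)CCC(=O)N1CCN(CCCOc2cc3c(Nc4ccc(F)c(Cl)c4)ncnc3cc2OC)CC1` is a quinazoline-type anilide bearing an ester side chain. Among the compounds with values here, in a functional assay on A549 cells (Homo sapiens) for cytotoxicity, read by MTT assay, with a stated time of 24 h, tested at 40 uM (a lower number here means a stronger effect, a higher number a weaker effect of the compound at the concentration tested), compound 2 gives 88.6%, the highest of the two numbers measured so far. Its nearest neighbour, compound 1 `CCCCCCOC(=O)CCC(=O)N1CCN(CCCOc2cc3c(Nc4ccc(F)c(Cl)c4)ncnc3cc2OC)CC1`, gives 74.2% in this assay, and the step of a number 14.4 percentage points higher from compound 1 to compound 2 (beyond the scatter) is a modest weakening of the effect.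

Compound 3 `CCCCCCCCCCCCCCCCCCCCOC(=O)CCC(=O)N1CCN(CCCOc2cc3c(Nc4ccc(F)c(Cl)c4)ncnc3cc2OC)CC1` extends the same chain once more: hexyl in place of hydrogen on a saturated chain carbon, ten or more bonds along the chain from an oxygen next to a carbonyl group. Within the data shown here, only the step from compound 1 to compound 2 bears on this change, and it pointed toward a weaker effect. A further but smaller rise is therefore expected, a number 6.4 percentage points higher from compound 2 to compound 3 (within the scatter), giving compound 3 an estimated 95% with a likely range from 85% to 103%.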

Compound 3, a percentage reported as activity, at one concentration (the size of the read-out at that concentration, not a potency): 87.1%
Estimate against measurement, compound 3: 7.9 percentage points above, within the range that was stated.
By their numbers in this assay, from the lowest: compound 1; then compounds 3 and 2 (each within the scatter of the next).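

At this far end of the ester chain, adding hexyl gives a number 1.5 percentage points lower from compound 2 to compound 3 (within the scatter) in this assay, so the extra carbons make no readable difference here. The earlier step, a number 14.4 percentage points higher from compound 1 to compound 2 (beyond the scatter), therefore does not carry on with this further lengthening, and compound 2 and compound 3 cannot be told apart. Nothing available explains this flat result. Still open, from the compounds shown here alone, is how a butyl ester would read, and whether an amine or a carboxylic acid in place of the long chain would shift the number.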